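A few compounds are considered here, and "the series" means these few. Any claim that something is new, unique, unknown or untested is made for them only; others in the source may bear on it.

Measured in a functional assay on SMMC-7721 cells (Homo sapiens) for cytotoxicity, read by MTT assay, with a stated time of 24 h; a lower number here means a stronger inhibitor, a higher number a weaker inhibitor:
- compound 1 `COc1cc(/C=C2\CN(S(=O)(=O)c3ccc(F)cc3)C/C(=C\c3cc(OC)c(OC)c(OC)c3)C2=O)cc(OC)c1`: 5420 nM
- compound 2 `COc1cc(/C=C2\CN(S(=O)(=O)c3ccc(NC(C)=O)cc3)C/C(=C\c3ccccc3F)C2=O)cc(OC)c1`: 5210 nM
- compound 3 `COc1cc(/C=C2\CN(S(=O)(=O)c3ccc(NC(C)=O)cc3)C/C(=C\c3ccc(C#N)cc3)C2=O)cc(OC)c1OC`: 1730 nM

Of these three, compound 3 stands lowest at 1730 nM, and the other two lie beyond the scatter from it, on the weaker side. Compound 1 and compound 2 sit within the scatter of each other. Among the measured compounds shown here, no two of the measured compounds differ in only one place, so no measured step is available as a guide.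

The next compound is compound 4 `COc1cc(/C=C2\CN(S(=O)(=O)c3ccc(NC(C)=O)cc3)C/C(=C\c3cc(OC)c(OC)c(OC)c3)C2=O)cc(OC)c1`. In going from compound 3 to compound 4, 3,5-dimethoxyphenyl comes in place of 4-cyanophenyl on a double-bonded chain carbon bound to a double-bonded ring carbon: 3,5-dimethoxyphenyl in place of 4-cyanophenyl on a double-bonded chain carbon bound to a double-bonded ring carbon. The entering group is one that compound 1 (5420 nM) and compound 2 (5210 nM) also carry, and both show higher numbers than compound 3 (1730 nM). This is thin evidence, since those two compounds also differ from compound 4 elsewhere. A rise of moderate size is therefore expected, probably beyond the scatter. The expected change is a 2.3-fold higher number from compound 3 to compound 4 (0.36 log units; beyond the scatter), towards a weaker inhibitor. For compound 4 the estimated value is 4000 nM, with an expected range from 1900 nM to 8000 nM.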

Compound 4, half-maximal inhibitory concentration: 4200 nM
For compound 4 the middle estimate is 1.1-fold (0.02 log units) below the measured one; low and high end bracket the measured number.
By their numbers in this assay, from the lowest: compound 3; then compounds 4, 2 and 1 (each within the scatter of the next).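

In this assay, among the compounds shown here, 3,5-dimethoxyphenyl in place of 4-cyanophenyl on a double-bonded chain carbon bound to a double-bonded ring carbon gives a 2.4-fold higher number from compound 3 to compound 4 (0.39 log units; beyond the scatter), the first measured single-place change here that lies beyond the scatter. At that same place, 3,4,5-trimethoxyphenyl in place of 2-fluorophenyl gives a 1.2-fold lower number from compound 2 to compound 4 (0.09 log units; within the scatter), which lies within the scatter, so this place does not respond to every exchange of one aryl group for another, although the two changes were made with different groups on the other side of the shared core. Acetamido in place of fluoro on an aromatic carbon gives a 1.3-fold lower number from compound 1 to compound 4 (0.11 log units; within the scatter), also within the scatter, so this exchange shows no measurable effect on this background.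

Nothing available here explains any of these steps.

From the compounds shown here alone, it remains open whether the change from compound 3 to compound 4 reflects the loss of 4-cyanophenyl or the arrival of 3,5-dimethoxyphenyl, and an unsubstituted phenyl at this place would help to separate the two. Going by these compounds, it also remains open how a free amine or a carboxylic acid would compare with acetamido and fluoro on the aromatic carbon.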